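Cytotoxicity of compound 4: sulfamoyl loss

The source may report more compounds than this note shows. Statements on the series, on what has been measured and on what is new or still open speak of the compounds shown alone.

Measured in an ADME assay on MT4 cells (Homo sapiens) for cytotoxicity, read by MTT assay, with a stated time of 5 days; a higher number here means that more compound is tolerated, a lower number that less compound is tolerated:
compound 1 `COc1cc2nc([S+]([O-])CC(=O)Nc3ccc(Cl)cc3)nc(Nc3c(Cl)cc(/C=C/C#N)cc3Cl)c2cc1OC`: 14400 nM
compound 2 `COc1cc2nc([S+]([O-])CC(=O)Nc3ccccc3C#N)nc(Nc3c(Cl)cc(/C=C/C#N)cc3Cl)c2cc1OC`: > 206000 nM (a limit)
compound 3 `COc1cc2nc([S+]([O-])CC(=O)Nc3ccc(S(N)(=O)=O)cc3)nc(Nc3c(Cl)cc(/C=C/C#N)cc3Cl)c2cc1OC`: > 189000 nM (a limit)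

Compound 3 gives only a limit in this assay, (the limit of > 189000 nM in this assay, at which 1 of the 3 values shown sits). Compound 2 is likewise known only as a limit, (the limit of > 206000 nM in this assay, at which 1 of the 3 values shown sits). The next structure, compound 4 `COc1ccccc1NC(=O)C[S+]([O-])c1nc(Nc2c(Cl)cc(/C=C/C#N)cc2Cl)c2cc(OC)c(OC)cc2n1`, has 2-methoxyphenyl in place of 4-sulfamoylphenyl on an amide-type nitrogen.

Within the data shown here, three measured steps bear on this change. The two readable ones are large: an at least 14-fold higher number from compound 1 to compound 2 (1.15 log units; beyond the scatter) and an at least 13-fold higher number from compound 1 to compound 3 (1.11 log units; beyond the scatter). The third gives no size: a step that the two limits leave unreadable from compound 2 to compound 3. Compound 4 has neither the 4-chlorophenyl of compound 1 nor the 4-sulfamoylphenyl of compound 3, so it can be read against both ends of the series. A moderate move to a lower number is expected in this assay, with the estimated step being an at least 2.7-fold lower number from compound 3 to compound 4 (0.43 log units; beyond the scatter). A further limit remains possible. The estimate for compound 4 is 70000 nM, with an expected range of 15000 nM to 200000 nM.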

Compound 4, half-maximal cytotoxic concentration: > 204000 nM
Compound 4: a limit, no number; the forecaster's own chance of this, stated with the estimate: 40%; at least 2.9-fold (0.46 log units) between middle value and limit.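

Compound 4 is known only as a limit in this assay: the limit of > 204000 nM in this assay, at which 1 of the 4 values shown sits. Replacing 4-chlorophenyl with 2-methoxyphenyl on the amide-type nitrogen gives an at least 14-fold higher number from compound 1 to compound 4 (1.15 log units; beyond the scatter), so a third replacement of 4-chlorophenyl ends in a limit, and compound 1 remains the only one of the four with a number. The 2-methoxyphenyl carries neither sulfamoyl nor cyano, so the limit does not depend on either of those two groups on this phenyl ring.

The steps among compound 2, compound 3 and compound 4 cannot be read: all three are limits, and no order among them follows. From the compounds shown here alone, it remains open whether the number of compound 1 goes with the chloro group itself or with where it sits, a question that 2-chlorophenyl and 4-methoxyphenyl on the same nitrogen would address.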